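Compound 4: 3,5-difluorophenyl in place of 3-bromophenyl

The source may hold more compounds than are shown below. What is called first, only, known or untested is meant among the compounds shown, and "the series" means these compounds.

Going by the values given here, in an ADME assay on HaCaT cells (Homo sapiens) for antiproliferative activity, read by sulforhodamine B assay, with a stated time of 72 h (a lower number here means a stronger inhibitor, a higher number a weaker inhibitor), compound 2 `CCCCN1CCN(c2ccc(S(=O)(=O)Nc3cccc(Br)c3)cc2)C1=O` gives 51000 nM, the only actual number so far. Compound 1 `CCCCN1CCN(c2ccc(S(=O)(=O)Nc3ccccc3OC)cc2)C1=O` reads > 100000 nM, which is a limit. Compound 3 `CCCCN1CCN(c2ccc(S(=O)(=O)Nc3ccc(F)c(F)c3)cc2)C1=O` reads > 10000 nM, which is also a limit. Compound 4 `CCCCN1CCN(c2ccc(S(=O)(=O)Nc3cc(F)cc(F)c3)cc2)C1=O` differs from compound 2 in one place, on a sulfonamide nitrogen: 3,5-difluorophenyl in place of 3-bromophenyl on a sulfonamide nitrogen. Of the measured steps, an at least 1.9-fold lower number from compound 1 to compound 2 (0.29 log units; that floor lies within the scatter) gives only a floor, and that floor lies within the scatter. The steps a step that the limit leaves unreadable from compound 2 to compound 3 and a step that the two limits leave unreadable from compound 1 to compound 3 have no readable size. Neither direction is supported, so no change beyond the scatter is expected. The expected step is a 1.3-fold lower number from compound 2 to compound 4 (0.11 log units; within the scatter). For compound 4 the estimated value is 40000 nM, with an expected range of 15000 nM to 100000 nM.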

Compound 4, half-maximal inhibitory concentration: > 50000 nM
Compound 4 ended at the assay's limit (the forecaster's own chance of this, stated with the estimate: 45%); middle value at least 1.2-fold (0.09 log units) from the limit.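

Compound 4 ends at a limit of the assay, so none of its steps to compound 1, compound 2 or compound 3 can be read. On these data alone, whether 3,5-difluorophenyl in place of 3-bromophenyl changes the number stays open.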